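This account rests on a few compounds, and the source may have more. Where it says the series, first, only, none or still open, it means among the compounds named here.

Compound 1 `CC1=CC[C@H](C(C)(C)NC(=S)N/N=C/c2ccccc2)CC1` gives 84400 nM in a functional assay on MCF7 cells (Homo sapiens) for inhibition, read by sulforhodamine B assay, with a stated time of 48 h; on this read-out lower numbers stand for stronger inhibition of growth and higher numbers for weaker inhibition of growth.
Compound 2 `CC1=CC[C@H](C(C)(C)NC(=S)N/N=C/c2ccc(O)cc2)CC1` reaches only a limit in this assay, > 100000 nM, which is not a number.

Compound 2 therefore stands at the limit of > 100000 nM in this assay, at which 1 of the 2 values shown sits, so its growth inhibition is known only as weaker than the assay can report. Among the measured compounds shown here, the single measured step, an at least 1.1-fold higher number from compound 1 to compound 2 (0.07 log units; that floor lies within the scatter), came from putting a hydroxy group onto the aromatic ring of compound 1 and gave no gain. Compound 3 `COc1cc(/C=N/NC(=S)NC(C)(C)[C@H]2CC=C(C)CC2)ccc1O` differs from compound 2 by one further change: methoxy in place of hydrogen on an aromatic carbon. For the measured compounds named here, no measured step concerns a methoxy group, so the only guidance is that one added oxygen group left the number at or beyond the limit. Compound 3 is therefore expected to stay near that limit, with a step that the limit leaves unreadable from compound 2 to compound 3 as the estimated step. The estimated value for compound 3 in this assay is 120000 nM, within 50000 nM to 300000 nM.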

Compound 3, concentration for total growth inhibition: 63900 nM
The estimate for compound 3 lay 1.9-fold (0.27 log units) above the measured number, within the range that was stated.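

Methoxy on the aromatic carbon ortho to a hydroxy group brings the read-out in this assay down to a measured number, which the hydroxy group alone did not do for compound 2. The change gives an at least 1.5-fold lower number from compound 2 to compound 3 (0.19 log units; that floor lies within the scatter) and so shows only a floor for the step, one that stays within the usual scatter of this read-out. Its true size cannot be read because compound 2 has only a limit and not a number: the limit of > 100000 nM in this assay, at which 1 of the 3 values shown sits.

As far as these compounds go, whether an ethoxy group, a chlorine atom or an amine at this same position would move the number further remains open. Also open, from the compounds shown here alone, is whether the methoxy group would give a similar number on the ring without the hydroxy group.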